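A Butyl Chain in Place of Dimethylamino on the Core

This account rests on a few compounds, and the source may have more. Where it says the series, first, only, none or still open, it means among the compounds named here.

Of the compounds shown here, three sharing one core have been tested in a functional assay on HeLa cells (Homo sapiens) for antiproliferative activity, read by MTT assay, with a stated time of 96 h; on this read-out lower numbers stand for stronger inhibition and higher numbers for weaker inhibition. Compound 1 `CN(C)c1ccc(N2C(=O)NC3(CSC4=C3C(=O)c3ncccc3C4=O)C2=O)cc1` gives 10 nM, the second highest of the three numbers. Compound 2 `O=C1C2=C(C(=O)c3ncccc31)C1(CS2)NC(=O)N(c2ccc(Cl)cc2)C1=O` gives 2 nM, and compound 3 `O=C1C2=C(C(=O)c3ncccc31)C1(CS2)NC(=O)N(c2ccc([N+](=O)[O-])cc2)C1=O` gives 100 nM. The measured steps are a 5.0-fold lower number from compound 1 to compound 2 (0.70 log units; beyond the scatter), a 10-fold higher number from compound 1 to compound 3 (1.00 log units; beyond the scatter) and a 50-fold higher number from compound 2 to compound 3 (1.70 log units; beyond the scatter). Compound 4 `CCCCc1ccc(N2C(=O)NC3(CSC4=C3C(=O)c3ncccc3C4=O)C2=O)cc1` has not yet been measured. It differs from compound 1 in one place: butyl in place of dimethylamino on an aromatic carbon. For the measured compounds named here, no measured step exchanges a group for an alkyl chain, so only the width of change seen at this position is known. Because a 5.0-fold lower number from compound 1 to compound 2 (0.70 log units; beyond the scatter) and a 10-fold higher number from compound 1 to compound 3 (1.00 log units; beyond the scatter) run in opposite directions, no clear direction is expected for compound 4. The step of no change at the digits printed from compound 1 to compound 4 (within the scatter) is thus expected to stay near the scatter. Compound 4 is estimated at 10 nM, with a range from 2 nM to 50 nM.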

Compound 4, half-maximal inhibitory concentration: 90 nM
Compound 4: middle estimate off by 9.0-fold (0.95 log units), on the low side; measured number outside the range, above it.
By their numbers in this assay, from the lowest: compound 2; then compound 1; then compounds 4 and 3 (each within the scatter of the next).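

Exchanging dimethylamino for butyl is not a neutral change at this position in this assay: it gives a 9.0-fold higher number from compound 1 to compound 4 (0.95 log units; beyond the scatter). Butyl and nitro cannot be told apart here, with a 1.1-fold lower number from compound 3 to compound 4 (0.05 log units; within the scatter), while chloro stands well clear of butyl, with a 45-fold higher number from compound 2 to compound 4 (1.65 log units; beyond the scatter). No measurement at hand gives a reason for these steps.

On these data alone, whether a shorter chain such as methyl or a longer chain such as hexyl would behave like butyl stays open. So does where a carboxylic acid on the same aromatic carbon would fall.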